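Phenyl substitution and the expected number for compound 4

A few compounds are considered here, and "the series" means these few. Any claim that something is new, unique, unknown or untested is made for them only; others in the source may bear on it.

For the measured compounds named here, compound 1 `O=C1C2=C(C(=O)c3ncccc31)C1(CS2)NC(=O)N(c2ccccc2)C1=O` gives 1700 nM in a functional assay on SF-268 cells (Homo sapiens) for antiproliferative activity, read by MTT assay, with a stated time of 96 h (on this read-out lower numbers stand for stronger inhibition and higher numbers for weaker inhibition), the highest of the three numbers measured so far. Compound 2 `COc1ccc(N2C(=O)NC3(CSC4=C3C(=O)c3ncccc3C4=O)C2=O)cc1` gives 650 nM in this assay, and compound 3 `CCCCc1ccc(N2C(=O)NC3(CSC4=C3C(=O)c3ncccc3C4=O)C2=O)cc1` gives 400 nM there, so both substituted analogues sit lower than compound 1. Compound 4 `CN(C)c1ccc(N2C(=O)NC3(CSC4=C3C(=O)c3ncccc3C4=O)C2=O)cc1` differs from compound 1 by dimethylamino in place of hydrogen on an aromatic carbon. Going by the values given here, the steps that bear on this are a 2.6-fold lower number from compound 1 to compound 2 (0.42 log units; beyond the scatter) and a 4.3-fold lower number from compound 1 to compound 3 (0.63 log units; beyond the scatter): each puts a group at the same place on the phenyl and each lowers the number modestly, beyond the scatter. Dimethylamino is a third group of this kind, so a modest lowering is expected for compound 4, about a 2.8-fold lower number from compound 1 to compound 4 (0.45 log units; beyond the scatter). Compound 4 is therefore estimated at 600 nM, within a range of 280 nM to 1300 nM.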

Compound 4, half-maximal inhibitory concentration: 950 nM
The estimate for compound 4 lay 1.6-fold (0.20 log units) below the measured number; the measured number falls inside the stated range.
By their numbers in this assay, from the lowest: compounds 3, 2, 4 and 1 (each within the scatter of the next, the first and the last beyond it).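

At this place on the phenyl, dimethylamino does not separate from the hydrogen of compound 1 (a 1.8-fold lower number from compound 1 to compound 4 (0.25 log units; within the scatter)), whereas methoxy and butyl both did, so a group here does not by itself guarantee a step beyond the scatter. Dimethylamino and butyl do separate (a 2.4-fold higher number from compound 3 to compound 4 (0.38 log units; beyond the scatter)), while dimethylamino and methoxy do not (a 1.5-fold higher number from compound 2 to compound 4 (0.16 log units; within the scatter)). Nothing available explains these differences.

Open, from the compounds shown here alone, is whether a longer chain such as hexyl would follow butyl. Also open, going by these compounds, is where a primary amine or carboxylic acid at this place would fall.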